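Swapping the amide nitrogen group on a diarylamine core

A few compounds are considered here, and "the series" means these few. Any claim that something is new, unique, unknown or untested is made for them only; others in the source may bear on it.

Two compounds share a core in which a propanamide chain carries a diarylamine bearing two chlorine atoms. Compound 1 `CC(C(=O)NS(C)(=O)=O)c1ccccc1Nc1c(Cl)cccc1Cl` holds a methylsulfonyl group on its amide-type nitrogen, and in an assay on isolated protein for inhibition of interleukin-8 (Homo sapiens), with stated times of 15 min and 4 h (on this read-out higher numbers stand for weaker inhibition and lower numbers for stronger inhibition), compound 1 gives 13 nM. Compound 2 `CC(C(=O)NCCCN(C)C)c1ccccc1Nc1c(Cl)cccc1Cl` carries a 3-(dimethylamino)propyl group at the same place, and in this assay compound 2 gives 25 nM. The step of a 1.9-fold higher number from compound 1 to compound 2 (0.28 log units; within the scatter) lies within the scatter, so on the numbers shown compound 2 and compound 1 cannot be told apart, and compound 2 stands at the higher of the two numbers only nominally.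

Compound 3 `Cc1cccc(C)c1NC(=O)C(C)c1ccccc1Nc1c(Cl)cccc1Cl` changes the same position again: 2,6-dimethylphenyl in place of 3-(dimethylamino)propyl on an amide-type nitrogen. Within the data shown here, the only measured step that bears on this place is a 1.9-fold higher number from compound 1 to compound 2 (0.28 log units; within the scatter), which exchanged one amide nitrogen substituent for a very different one without a shift beyond the scatter. Among the measured compounds shown here, no step involving an aromatic group at this place has been measured. A step of about a 1.2-fold higher number from compound 2 to compound 3 (0.08 log units; within the scatter) is therefore expected, that is, none beyond the scatter, with a wide range. Compound 3 is estimated at 30 nM, between 8 nM and 120 nM.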

Compound 3, half-maximal inhibitory concentration: 600 nM
For compound 3 the middle estimate is 20-fold (1.30 log units) below the measured one; the measured number lies above the stated range.
By their numbers in this assay, from the lowest: compounds 1 and 2 (each within the scatter of the next); then compound 3.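

The position on the amide-type nitrogen does not accept every group equally: in this assay, 2,6-dimethylphenyl gives a 24-fold higher number from compound 2 to compound 3 (1.38 log units; beyond the scatter), and measured against methylsulfonyl it gives a 46-fold higher number from compound 1 to compound 3 (1.66 log units; beyond the scatter), both large steps toward weaker inhibition. The earlier pair suggested that this place might be forgiving, since two very different groups, methylsulfonyl and 3-(dimethylamino)propyl, left compound 1 and compound 2 within the scatter of each other, but that tolerance does not reach 2,6-dimethylphenyl. Nothing available explains why this group gives so much weaker inhibition.

The compounds shown leave open whether the loss goes with the six-membered aromatic ring itself or with the two methyl groups it carries, as compound 3 changes both at once compared with compound 2. A plain phenyl group at this place would speak to the role of the methyl groups, and a cyclohexyl group would show whether a ring of carbon that is not aromatic behaves in the same way.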